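One Oxygen More: Expected Cell Tolerance of Compound 4

The source may report more compounds than this note shows. Statements on the series, on what has been measured and on what is new or still open speak of the compounds shown alone.

Compound 1 `CCOC(=O)c1cc2c(CN(C)C)c(O)c(OC)cc2nc1CSc1ccc(F)cc1` gives 120 uM in an ADME assay on HepG2 2.2.15 cells (Homo sapiens) for cytotoxicity, read by MTT assay, with a stated time of 9 days; a higher number here means that more compound is tolerated, a lower number that less compound is tolerated.
Compound 2 `CCOC(=O)c1cc2c(CN(C)C)c(O)c(OC)cc2nc1C[S+]([O-])c1ccc(F)cc1` gives 90.4 uM in this assay.
Compound 3 `CCOC(=O)c1cc2c(Cn3ccnc3)c(O)c(OC)cc2nc1CSc1ccc(F)cc1` gives 202 uM in this assay.

Compound 4 `CCOC(=O)c1cc2c(Cn3ccnc3)c(O)c(OC)cc2nc1C[S+]([O-])c1ccc(F)cc1` has not yet been tested. It differs from compound 3 by a group of 9 heavy atoms (6 carbon, 1 oxygen, 1 fluorine, 1 sulfur; one six-membered aromatic ring of carbon only) in place of a group of 8 heavy atoms (6 carbon, 1 fluorine, 1 sulfur; one six-membered aromatic ring of carbon only), on a saturated chain carbon bound to an aromatic carbon. The same change has already been made once among these compounds, from compound 1 to compound 2, as a group of 9 heavy atoms (6 carbon, 1 oxygen, 1 fluorine, 1 sulfur; one six-membered aromatic ring of carbon only) in place of a group of 8 heavy atoms (6 carbon, 1 fluorine, 1 sulfur; one six-membered aromatic ring of carbon only), on a saturated chain carbon bound to an aromatic carbon, and there it gave a 1.3-fold lower number from compound 1 to compound 2 (0.12 log units; within the scatter). The two cores differ by 1H-imidazol-1-yl in place of dimethylamino on a saturated chain carbon bound to an aromatic carbon; that core change alone gave a 1.7-fold higher number from compound 1 to compound 3 (0.23 log units; within the scatter). The place of the change is the same word for word in both pairs, so it counts as the same change. In this assay compound 4 is expected to show a 1.3-fold lower number from compound 3 to compound 4 (0.12 log units; within the scatter), resting on a 1.3-fold lower number from compound 1 to compound 2 (0.12 log units; within the scatter). Compound 4 is therefore estimated at 155 uM, with a likely range from 80 uM to 300 uM.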

Compound 4, half-maximal toxic concentration: 160 uM
For compound 4 the middle estimate is 1.0-fold (0.01 log units) below the measured one; the range from low to high includes it.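

In this assay the added oxygen on the sulfur-bearing group repeats on the core of compound 3, giving a 1.3-fold lower number from compound 3 to compound 4 (0.10 log units; within the scatter): the same change on two cores in this assay, a 1.3-fold lower number (0.12 log units; within the scatter) from compound 1 to compound 2 and a 1.3-fold lower number (0.10 log units; within the scatter) from compound 3 to compound 4, 1.1-fold (0.02 log units) apart, within the scatter of two such steps
Likewise, 1H-imidazol-1-yl in place of dimethylamino repeats with the added oxygen present, giving a 1.8-fold higher number from compound 2 to compound 4 (0.25 log units; within the scatter): the same change on two cores in this assay, a 1.7-fold higher number (0.23 log units; within the scatter) from compound 1 to compound 3 and a 1.8-fold higher number (0.25 log units; within the scatter) from compound 2 to compound 4, 1.1-fold (0.02 log units) apart, within the scatter of two such steps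
Among these compounds, each change therefore carries from one core to the other here, but every step lies within the scatter, so this shows only that neither change produced a clear shift on these two cores, not that either has a real effect of its own.

On these data alone, it stays open whether this holds for other amines on that chain carbon, such as morpholine or piperidine. A second oxygen on the sulfur also remains untested among the compounds shown.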